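The source may report more compounds than this note shows. Statements on the series, on what has been measured and on what is new or still open speak of the compounds shown alone.

Measured compounds in an assay on isolated protein for inhibition of Indoleamine 2,3-dioxygenase 1 (Homo sapiens), read by spectrophotometry; a lower number here means a stronger inhibitor, a higher number a weaker inhibitor:
- compound 1 `O/N=C(/Nc1cccc(C(F)(F)F)c1)c1ccc2occc2c1`: 1200 nM
- compound 2 `O/N=C(/Nc1cccc(Cc2ccccc2)c1)c1ccc2occc2c1`: a limit of the assay, > 30000 nM
- compound 3 `O/N=C(/Nc1cccc(COc2ccccc2)c1)c1ccc2occc2c1`: a limit of the assay, > 30000 nM

Compound 3 stands at the upper limit of the assay, where it shares the limit of > 30000 nM in this assay, at which 2 of the 3 values shown sit, with one other member of the series; no number is known for it, only that it lies beyond the range the assay reports.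

The next compound, compound 4 `O/N=C(/Nc1cccc(-c2ccccc2)c1)c1ccc2occc2c1`, differs from compound 3 by phenyl in place of phenoxymethyl on an aromatic carbon.

Going by the values given here, two measured steps bear on substitution at this position. From compound 1 to compound 2 the step was an at least 25-fold higher number from compound 1 to compound 2 (1.39 log units; beyond the scatter), and from compound 1 to compound 3 it was an at least 25-fold higher number from compound 1 to compound 3 (1.39 log units; beyond the scatter). Both replacements of trifluoromethyl by a substituent carrying a phenyl ring removed measurable inhibition. The step from compound 2 to compound 3 is a step that the two limits leave unreadable from compound 2 to compound 3, so the two limits give no reading of how phenyl and phenoxy compare on the chain carbon. Phenyl bound directly to the aromatic carbon has not been measured; the only anchor for a number in this assay is compound 1 at 1200 nM. Both phenyl-bearing analogues, compound 2 and compound 3, sit at the limit of the assay.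

For compound 4 a weak inhibitor is expected, 12000 nM with a range from 2500 nM to 40000 nM, and a fair chance that only a limit is reported. The expected step from compound 3 to compound 4 is therefore an at least 2.5-fold lower number from compound 3 to compound 4 (0.39 log units; beyond the scatter), little more than a return into the measurable range, if at all.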

Compound 4, half-maximal inhibitory concentration: 11000 nM
For compound 4 the middle estimate is 1.1-fold (0.04 log units) above the measured one; the range from low to high includes it.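

In this assay, a phenyl group bound directly to this aromatic carbon gives a measurable number, unlike the two larger phenyl-bearing substituents, with an at least 2.7-fold lower number from compound 3 to compound 4 (0.43 log units; beyond the scatter) for phenyl in place of phenoxymethyl and an at least 2.7-fold lower number from compound 2 to compound 4 (0.43 log units; beyond the scatter) for phenyl in place of benzyl. Compound 2 and compound 3 remain limits of the assay rather than numbers, so the true size of these two gains stays unknown: the limit of > 30000 nM in this assay, at which 2 of the 4 values shown sit.

Carrying a phenyl ring at this position therefore does not by itself remove measurable inhibition, yet phenyl does not match trifluoromethyl, with a 9.2-fold higher number from compound 1 to compound 4 (0.96 log units; beyond the scatter).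

Open, going by these compounds, is how a chlorine atom, a methoxy group or a nitrile on this aromatic carbon would stand against compound 1 and compound 4 in this assay. Also open, on these data alone, is whether a carboxylic acid or an amine on the phenyl ring of compound 4 would move its number in either direction.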